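From Piperidinyl to 1,2-Thiazolyl: An Expected Gain

The source may hold more compounds than are shown below. What is called first, only, known or untested is meant among the compounds shown, and "the series" means these compounds.

Compound 1 `CCC(C)(C)Cc1c[nH]c(CCc2ccc(-c3cccnc3)cc2)n1` gives 4.3 nM in a functional assay on HEK293 cells for agonist activity at Bombesin receptor subtype-3 (Mus musculus), read by luminescence and calcium flux, with a stated time of 10 min; on this read-out lower numbers stand for an effect already at smaller amounts and higher numbers for an effect only at larger amounts of compound.
Compound 2 `CCC(C)(C)Cc1c[nH]c(CCc2ccc(N3CCCCC3)cc2)n1` gives 28 nM in this assay.

Compound 2 stands highest of the two numbers measured, with the step of a 6.5-fold higher number from compound 1 to compound 2 (0.81 log units; beyond the scatter) separating it from compound 1. Compound 3 `CCC(C)(C)Cc1c[nH]c(CCc2ccc(-c3ccns3)cc2)n1` differs from compound 2 by 1,2-thiazol-5-yl in place of piperidin-1-yl on an aromatic carbon. Among the compounds with values here, the one measured step that bears on this is a 6.5-fold higher number from compound 1 to compound 2 (0.81 log units; beyond the scatter), where an aromatic ring gave way to a non-aromatic one and the number rose. Since compound 3 brings an aromatic ring back, a step of roughly that size in the opposite direction, a 4.7-fold lower number from compound 2 to compound 3 (0.67 log units; beyond the scatter), is expected. Compound 3 is therefore estimated at 6 nM, with a range from 2 nM to 20 nM.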

Compound 3, half-maximal effective concentration: 3.1 nM
Compound 3: middle estimate off by 1.9-fold (0.29 log units), on the high side, and the stated range covers the measured number.
By their numbers in this assay, from the lowest: compounds 3 and 1 (each within the scatter of the next); then compound 2.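

With 1,2-thiazol-5-yl on the aromatic carbon para to a large group, the result is a 9.0-fold lower number from compound 2 to compound 3 (0.96 log units; beyond the scatter), so the gain over piperidin-1-yl is not confined to pyridin-3-yl. Exchanging one aromatic ring for the other gives a 1.4-fold lower number from compound 1 to compound 3 (0.14 log units; within the scatter), so the five-membered and six-membered aromatic rings cannot be told apart here. No evidence is available to explain the difference from piperidin-1-yl. It remains open whether a morpholin-4-yl group would behave like piperidin-1-yl, and whether a plain phenyl ring, with no hetero atom, would match the two aromatic rings shown.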